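From 2,5-dioxopyrrolidin-1-yl to propanoylamino in cytotoxicity

The compounds below may be only part of what the source reports. "The series", "measured", "known", "first", "only" and "open" are said of these compounds alone.

Compound 1, `O=C1O[C@@H](CN2CCC(c3ccc(F)cc3)CC2)CN1c1ccc(-n2cc(-c3ccccn3)cn2)c(F)c1`, reaches in an ADME assay on HEK293-A cells (Homo sapiens) for cytotoxicity, read by MTT assay, with a stated time of 48 h (on this read-out lower numbers stand for stronger inhibition and higher numbers for weaker inhibition), only the assay limit > 400 ug/mL.
Compound 2, `O=C1CCC(=O)N1C[C@H]1CN(c2ccc(-n3cc(-c4ccccn4)cn3)c(F)c2)C(=O)O1`, reaches in this assay only the assay limit > 400 ug/mL.
Compound 3, `O=C1O[C@@H](CSc2cccs2)CN1c1ccc(-n2cc(-c3ccccn3)cn2)c(F)c1`, reaches in this assay only the assay limit > 400 ug/mL.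

All three measured compounds share one core and differ only in the group carried on the saturated chain carbon bound to a saturated ring carbon. None of them gives a number: every value is a limit, as the limit of > 400 ug/mL in this assay, at which 3 of the 3 values shown sit, records. Within the data shown here, compound 2 therefore stands at that limit, and its only neighbouring step, a step that the two limits leave unreadable from compound 2 to compound 3, cannot be read in either direction.

Compound 4, `CCC(=O)NC[C@H]1CN(c2ccc(-n3cc(-c4ccccn4)cn3)c(F)c2)C(=O)O1`, is the next member. Against compound 2 the change is propanoylamino in place of 2,5-dioxopyrrolidin-1-yl on a saturated chain carbon bound to a saturated ring carbon.

Among the measured compounds shown here, no measured step gives a readable size, so there is no basis for expecting a move beyond the scatter in this assay in either direction. The expectation for compound 4 is that it too will sit at or beyond the limit, with the step from compound 2 estimated as a step that the limit leaves unreadable from compound 2 to compound 4. Compound 4 is thus estimated at 450 ug/mL, within a range from 200 ug/mL to 1000 ug/mL.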

Compound 4, half-maximal inhibitory concentration: 389 ug/mL
The estimate for compound 4 lay 1.2-fold (0.06 log units) above the measured number; the measured number falls inside the stated range.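

In this assay compound 4 is the only compound shown that gives a number rather than a limit, 389 ug/mL, so a group on this saturated chain carbon bound to a saturated ring carbon can yield a readable value. Replacing either earlier group with propanoylamino gives an at least 1.0-fold lower number from compound 2 to compound 4 (0.01 log units; that floor lies within the scatter) and an at least 1.0-fold lower number from compound 3 to compound 4 (0.01 log units; that floor lies within the scatter), and neither step shows a move beyond the scatter. These two steps are floors and not sizes, and the step from compound 2 to compound 3 cannot be read at all, because the other values are limits: the limit of > 400 ug/mL in this assay, at which 3 of the 4 values shown sit.

Among these compounds, the one step from compound 2 to compound 4 swaps a ring without a hydrogen-bond donor for an open chain with one, so it leaves open whether the ring, the amide hydrogen or both bear on the value. On these data alone, whether a free amine, a carboxylic acid or a longer acyl chain such as butanoylamino on the same carbon would give a number beyond the scatter from compound 4 also stays open.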